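Swapping methoxy for trifluoromethyl on the aryl piperazine

A few compounds are considered here, and "the series" means these few. Any claim that something is new, unique, unknown or untested is made for them only; others in the source may bear on it.

This small set shares one core and varies only the aromatic ring on the piperazine nitrogen. Compound 1 `COc1cccc(N2CCN(C(=O)CN3C(=O)CC(C)(c4ccccc4)C3=O)CC2)c1` gives 100 mg/kg in a functional assay on the whole organism (strain CD-1) with Mus musculus as the target, with a stated time of 0.5 h (a lower number here means that less compound is needed, a higher number that more compound is needed for the effect), the lowest of the two numbers measured. Compound 3 `CC1(c2ccccc2)CC(=O)N(CC(=O)N2CCN(c3cccc(Cl)c3Cl)CC2)C1=O` gives 300 mg/kg, a step of a 3.0-fold higher number from compound 1 to compound 3 (0.48 log units; beyond the scatter). Compound 2 `CC1(c2ccccc2)CC(=O)N(CC(=O)N2CCN(c3ccccc3Cl)CC2)C1=O` was reported as "not active" (no number reported), so no number exists for it.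

Compound 4 `CC1(c2ccccc2)CC(=O)N(CC(=O)N2CCN(c3cccc(C(F)(F)F)c3)CC2)C1=O` has not yet been tested. It differs from compound 1 by trifluoromethyl in place of methoxy on an aromatic carbon. Among the measured compounds shown here, the only measured step that bears on changing this aromatic ring is the one from compound 1 to compound 3, which was a modest worsening, while compound 2 shows that a further ring change can remove the effect entirely. For the measured compounds named here, no measured compound carries a trifluoromethyl group, so the direction rests on the general finding that changing this ring has so far only raised the number or lost the effect. For compound 4 the expected value is therefore 200 mg/kg, with a likely range from 70 mg/kg to 600 mg/kg. This estimate means a step of a 2.0-fold higher number from compound 1 to compound 4 (0.30 log units; within the scatter), expected to be at most a modest worsening.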

Compound 4, minimum effective dose: "not active" (no number reported)
No number was reported for compound 4; the estimate stays without a comparison.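

Among the compounds shown here, compound 4 was reported as not active, without a number, so no step from compound 1 to compound 4 can be read. The compounds shown leave open how the aromatic ring's substituents govern the effect in this assay. No supporting data here explain this result.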